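Dropping the Methoxy Group from the Aryl Ring

This account rests on a few compounds, and the source may have more. Where it says the series, first, only, none or still open, it means among the compounds named here.

Compound 1, `COc1cccc(-c2nc3c(-c4ccc(Cl)cc4)n[nH]c3c(=O)n2NC(=O)c2ccncc2)c1`: 46%
Compound 2, `O=C(Nn1c(-c2cccc([N+](=O)[O-])c2)nc2c(-c3ccc(Cl)cc3)n[nH]c2c1=O)c1ccccc1`: 87.8%
Compound 3, `COc1cccc(-c2nc3c(-c4ccc(Cl)cc4)n[nH]c3c(=O)n2NC(=O)c2ccccc2)c1`: 87.3%

The three compounds share one core and were all tested in a functional assay on HT-29 cells (Homo sapiens) for cytotoxicity, read by sulforhodamine B assay, with a stated time of 2 days, tested at 100 uM; on this read-out higher numbers stand for more inhibition at the one concentration tested (going by the name of the read-out) and lower numbers for less inhibition. Compound 3 stands second highest of the three numbers. Its nearest neighbour is compound 2, whose value lies within the scatter of it, while compound 1 lies far below it, with a number 41.3 percentage points higher from compound 1 to compound 3 (beyond the scatter) when phenyl replaces pyridin-4-yl on the carbonyl carbon.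

Compound 4, `O=C(Nn1c(-c2ccccc2)nc2c(-c3ccc(Cl)cc3)n[nH]c2c1=O)c1ccccc1`, has not yet been measured. It differs from compound 3 in one place: hydrogen in place of methoxy on an aromatic carbon. Among the measured compounds shown here, the one measured step that bears on this change is the one on the same aromatic ring, where a number 0.5 percentage points lower from compound 2 to compound 3 (within the scatter) when methoxy replaced nitro; two quite different groups there gave values that cannot be told apart. The step at the carbonyl carbon sits elsewhere in the molecule and says nothing about this ring. The expected step in this assay is therefore small, a number 5.3 percentage points lower from compound 3 to compound 4 (within the scatter), and should stay within the scatter. Compound 4 is thus estimated at 82%, with a range from 60% to 95%.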

Compound 4, a percentage reported as inhibition, at one concentration (the size of the read-out at that concentration, not a potency): 92%
Compound 4: the middle estimate sits 10 percentage points below what was measured, within the range that was stated.
By their numbers in this assay, from the lowest: compound 1; then compounds 3, 2 and 4 (each within the scatter of the next).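

In this assay, taking the substituent off this ring altogether, the change from 3-methoxyphenyl to phenyl, gives a number 4.7 percentage points higher from compound 3 to compound 4 (within the scatter) and the change from the nitro-bearing ring to phenyl gives a number 4.2 percentage points higher from compound 2 to compound 4 (within the scatter) on the same read-out. The earlier compounds had shown only that methoxy and nitro could not be told apart on this aromatic carbon; compound 4 adds hydrogen to that set, so among compounds 2, 3 and 4 neither group separates from having no group there at all, while the step beyond the scatter remains the one at the carbonyl carbon, a number 41.3 percentage points higher from compound 1 to compound 3 (beyond the scatter) in the same assay. No measurement is at hand that would say why this position shows so little difference.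

From the compounds shown here alone, these readings come from one concentration and give no potency, and it remains open whether an amine, a carboxylic acid or a longer chain on this aromatic carbon would stay within the scatter as well. Also open, going by these compounds, is whether hydrogen in place of methoxy would read the same with pyridin-4-yl on the carbonyl carbon, as in compound 1 at 46% in this series.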